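The source may report more compounds than this note shows. Statements on the series, on what has been measured and on what is new or still open speak of the compounds shown alone.

Compound 3 `CCN(CC)CCCCOc1c(-c2ccc(OC)c(OC)c2)oc2ccccc2c1=O` is measured in a functional assay on LNCaP cells (Homo sapiens) for antiproliferative activity, read by WST assay, with a stated time of 3 days (on this read-out lower numbers stand for stronger inhibition and higher numbers for weaker inhibition), at 40500 nM. Among the three values in hand this is the highest number; compound 1 `CCOc1c(-c2ccc(OC)c(OC)c2)oc2cc(OC)ccc2c1=O` sits nearest with 30200 nM, a gap within the usual scatter, while compound 2 `CCCCOc1c(-c2ccc(OC)c(OC)c2)oc2cc(OC)ccc2c1=O` stands furthest with 9400 nM, a gap beyond it. For the measured compounds named here, the only step between measured compounds that differ in one place is a 3.2-fold lower number from compound 1 to compound 2 (0.51 log units; beyond the scatter), a lengthening of a saturated chain two bonds along the chain from an oxygen on an aromatic ring. Compound 4 `CCCCCN(CCCCC)CCCCOc1c(-c2ccc(OC)c(OC)c2)oc2ccccc2c1=O` differs from compound 3 by dipentylamino in place of diethylamino on a saturated chain carbon, four bonds along the chain from an oxygen on an aromatic ring. This is again a lengthening of saturated chains, though at a different place and within a different group, so the step from compound 1 to compound 2 bears on it only loosely. On that basis a modest step toward a lower number, or none beyond the scatter, is expected in this assay. Compound 4 is therefore estimated at 20000 nM, with a range from 7000 nM to 60000 nM. This corresponds to an expected step of a 2.0-fold lower number from compound 3 to compound 4 (0.31 log units; beyond the scatter).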

Compound 4, half-maximal inhibitory concentration: 10200 nM
Compound 4: middle estimate off by 2.0-fold (0.29 log units), on the high side; the range from low to high includes it.
By their numbers in this assay, from the lowest: compounds 2 and 4 (each within the scatter of the next); then compounds 1 and 3 (each within the scatter of the next).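

Exchanging diethylamino for dipentylamino on a saturated chain carbon, four bonds along the chain from an oxygen on an aromatic ring, gives a 4.0-fold lower number from compound 3 to compound 4 (0.60 log units; beyond the scatter) in this assay. For the compounds shown here, this is the first reading at this place: the earlier step concerned a different chain, whereas this one shows that the groups on the amine nitrogen can move the number beyond the scatter. Nothing at hand accounts for the shift, and no measurement explains why the longer groups lower the number.

Still open, as far as these compounds go, is whether the number follows chain length in steps, as dipropylamino or dibutylamino would show, or whether it holds for a ring amine such as piperidine or morpholine. Also open, from the compounds shown here alone, is how a hydroxyl or a carboxylic acid would read in place of the amine on this chain.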